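Benzyl to 2-methoxyethyl on compound 2

A few compounds are considered here, and "the series" means these few. Any claim that something is new, unique, unknown or untested is made for them only; others in the source may bear on it.

Measured in a functional assay on KB cells (Homo sapiens) for inhibition (on this read-out higher numbers stand for weaker inhibition and lower numbers for stronger inhibition), so far:
- compound 1 `NC(=S)c1c(N)n(COCc2ccccc2)c2ncnc(N)c12` gives 225000 nM as a number
- compound 2 `NC(=O)c1c(N)n(COCc2ccccc2)c2ncnc(N)c12` gives > 100000 nM as a limit

For compound 2 the reading > 100000 nM is a limit of the assay and not a number. The series thus holds the limit of > 100000 nM in this assay, at which 1 of the 2 values shown sits, and offers no exact starting point for the next step.

Compound 3 `COCCOCn1c(N)c(C(N)=O)c2c(N)ncnc21` keeps the shared core and changes the chain, benzyl to 2-methoxyethyl, described as methoxymethyl in place of phenyl on a saturated chain carbon bound to an oxygen on a saturated carbon in full. Within the data shown here, the one measured step, a step that the limit leaves unreadable from compound 1 to compound 2, concerns a group on an aromatic carbon and not the chain, so it gives no measure for this change. Among the measured compounds shown here, since compound 1 gives 225000 nM as the only reading that is a number, no step beyond the scatter is expected in this assay in either direction. A further limit for compound 3 would not surprise. The expected change is a step that the limit leaves unreadable from compound 2 to compound 3 and remains an estimate. Compound 3 is estimated at 150000 nM with an expected range of 50000 nM to 400000 nM in this estimate.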

Compound 3, half-maximal inhibitory concentration: > 100000 nM
Compound 3: a limit, no number; the forecaster's own chance of this, stated with the estimate: 65%; the middle value is on the limit's open side.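

In this assay compound 3 gives > 100000 nM, which is a limit and not a number. Compound 2 also gives only a limit, so no step can be read between compound 2 and compound 3, and the series holds: the limit of > 100000 nM in this assay, at which 2 of the 3 values shown sit.

The compounds shown leave open whether benzyl to 2-methoxyethyl changes inhibition at all, in either direction.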